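An acetal in place of a pyridinyl carbonyl

A few compounds are considered here, and "the series" means these few. Any claim that something is new, unique, unknown or untested is made for them only; others in the source may bear on it.

Compound 1 `CCCCCCCC/C=C\CCCCCCC(=O)c1ccccn1` is a long unsaturated chain that ends in a (pyridin-2-yl)carbonyl group. In an assay on isolated protein for inhibition of Fatty-acid amide hydrolase 1 (Homo sapiens) (a lower number here means a stronger inhibitor, a higher number a weaker inhibitor), compound 1 gives > 100000 nM, which is a limit of the assay rather than a measured number. Compound 1 thus stands at the limit of > 100000 nM in this assay, at which 1 of the 2 values shown sits. Compound 2 `O=C(CCCCCCCCc1ccccc1)c1nc2ncccc2o1` carries a different aromatic ring on its carbonyl and a saturated chain ending in a phenyl ring; in this assay compound 2 gives 0.52 nM. Compound 3 `CCCCCCCC/C=C\CCCCCCCC(OC)OC` is not yet measured and differs from compound 1 by 2,2-dimethoxyethyl in place of (pyridin-2-yl)carbonyl on a saturated chain carbon, six bonds along the chain from a double-bonded chain carbon. For the measured compounds named here, no measured step covers this change, so the expectation can rest only on where compound 1 stands. With compound 1 already at the limit (the limit of > 100000 nM in this assay, at which 1 of the 2 values shown sits), the step of a number no higher from compound 1 to compound 3 (the limit leaves the size open) is expected to stay within the scatter, and compound 3 is expected most likely to return another limit. Compound 3 is estimated at 100000 nM, within 20000 nM to 500000 nM.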

Compound 3, inhibition constant: > 300000 nM
Compound 3: no number, only a limit (the forecaster's own chance of this, stated with the estimate: 80%); middle value at least 3.0-fold (0.47 log units) away from the limit.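

In this assay, compound 1 and compound 3 each give only a limit of the assay and no number, so the step between them cannot be read. Going by these compounds, how strong either inhibitor is, and whether 2,2-dimethoxyethyl in place of (pyridin-2-yl)carbonyl changes that at all, stays open.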